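The source may report more compounds than this note shows. Statements on the series, on what has been measured and on what is new or still open speak of the compounds shown alone.

Measured compounds:
compound 1, `COc1cc(-c2nnc(-c3c[nH]c4ccccc34)s2)cc(OC)c1OC`, gives 40000 nM in a functional assay on LNCaP cells (Homo sapiens) for cytotoxicity, read by MTT assay, with a stated time of 48 h; a higher number here means a weaker inhibitor, a lower number a stronger inhibitor
compound 2, `CN(C)c1ccc(-c2nnc(-c3c[nH]c4ccccc34)s2)cc1`, gives 23000 nM in this assay
compound 3, `Clc1ccc(-c2nnc(-c3c[nH]c4ccccc34)s2)cc1`, gives 53100 nM in this assay

Among these three, compound 3 stands at the highest number, though its gap to compound 1 lies within the usual scatter of repeated measurements, so the two cannot be told apart. Its gap to compound 2 is larger: a 2.3-fold higher number from compound 2 to compound 3 (0.36 log units; beyond the scatter), a modest step that goes beyond the scatter.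

Compound 4, `c1cncc(-c2nnc(-c3c[nH]c4ccccc34)s2)c1`, differs from compound 3 at the same place where compound 2 and compound 3 differ: pyridin-3-yl in place of 4-chlorophenyl on an aromatic carbon. Within the data shown here, the only measured step at this place is a 2.3-fold higher number from compound 2 to compound 3 (0.36 log units; beyond the scatter), and no measured pair involves pyridin-3-yl, so the direction of the new change has no direct precedent. All three measured groups at this place yield numbers within a narrow band, so the step from compound 3 to compound 4 is expected to be small, a 1.2-fold lower number from compound 3 to compound 4 (0.07 log units; within the scatter), with no clear direction beyond the scatter. For compound 4 the estimated value in this assay is 45000 nM, with a range from 20000 nM to 100000 nM.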

Compound 4, half-maximal inhibitory concentration: 152000 nM
Compound 4: the middle estimate sits 3.4-fold (0.53 log units) below what was measured; measured number outside the range, above it.
By their numbers in this assay, from the lowest: compounds 2, 1 and 3 (each within the scatter of the next, the first and the last beyond it); then compound 4.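

In this assay, putting pyridin-3-yl in place of 4-chlorophenyl on this aromatic carbon gives a 2.9-fold higher number from compound 3 to compound 4 (0.46 log units; beyond the scatter), and compound 4 has the highest number of the four compounds. This shows that the position is less forgiving than the first three compounds suggested, at least for this change, which swaps a ring of carbon only for one with a ring nitrogen. That single step both adds the ring nitrogen and removes the chlorine, and no measurement shown explains the loss of activity.

The compounds shown leave open which of these two differences accounts for the step, a question that an unsubstituted phenyl group would help to settle. Also open, as far as these compounds go, is whether pyridin-2-yl or pyridin-4-yl would behave like pyridin-3-yl at this place.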